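The source may hold more compounds than are shown below. What is called first, only, known or untested is meant among the compounds shown, and "the series" means these compounds.

Compound 1 `Cc1ccc(NC2=CC(=O)c3nc4n(c3C2=O)[C@H]2OC[C@@H](O)[C@H]2OC4)cc1C` — 2690 nM
Compound 2 `O=C1C=C(NCc2ccccc2)C(=O)c2c1nc1n2[C@H]2OC[C@@H](O)[C@H]2OC1` — > 8000 nM
Compound 3 `CCCc1ccc(NC2=CC(=O)c3nc4n(c3C2=O)[C@H]2OC[C@@H](O)[C@H]2OC4)cc1` — 4990 nM

Three compounds sharing one core were tested in a functional assay on HeLa cells (Homo sapiens) for inhibition, read by sulforhodamine B assay; on this read-out higher numbers stand for weaker inhibition and lower numbers for stronger inhibition. Compound 3 holds the highest of the two numbers shown, yet its distance to compound 1, a 1.9-fold higher number from compound 1 to compound 3 (0.27 log units; within the scatter), sits within the scatter. For compound 2 the assay reports only a limit, (the limit of > 8000 nM in this assay, at which 1 of the 3 values shown sits). The step from compound 2 onward, an at least 1.6-fold lower number from compound 2 to compound 3 (0.20 log units; that floor lies within the scatter), rests on that limit, and the larger step of an at least 2.9-fold higher number from compound 1 to compound 2 (0.47 log units; beyond the scatter) concerns a benzyl that neither compound 3 nor compound 4 carries.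

The next compound, compound 4 `CCOc1ccccc1NC1=CC(=O)c2nc3n(c2C1=O)[C@H]1OC[C@@H](O)[C@H]1OC3`, differs from compound 3 in one place: 2-ethoxyphenyl in place of 4-propylphenyl on an amine nitrogen. Among the measured compounds shown here, the only step that matches this kind of change, one phenyl group swapped for another on the amine nitrogen, is the step from compound 1 to compound 3, which stayed within the scatter. Compound 4 is therefore expected to show no step beyond the scatter, a 1.1-fold lower number from compound 3 to compound 4 (0.04 log units; within the scatter). Compound 4 is estimated at 4500 nM, with a range from 1500 nM to 12000 nM.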

Compound 4, half-maximal inhibitory concentration: 6040 nM
Compound 4: middle estimate off by 1.3-fold (0.13 log units), on the low side, within the range that was stated.
By their numbers in this assay, from the lowest: compounds 1, 3 and 4 (each within the scatter of the next, the first and the last beyond it). At a limit, above all of these: compound 2.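

On the amine nitrogen, 2-ethoxyphenyl brings a hydrogen-bond acceptor that 4-propylphenyl lacks, yet in this assay this exchange gives a 1.2-fold higher number from compound 3 to compound 4 (0.08 log units; within the scatter). Among the compounds shown here, the larger step, a 2.2-fold higher number from compound 1 to compound 4 (0.35 log units; beyond the scatter), is modest but beyond the scatter, the first step among the three phenyl-bearing compounds to clear it, though compound 3 stays within the scatter of both compound 1 and compound 4. The step of an at least 1.3-fold lower number from compound 2 to compound 4 (0.12 log units; that floor lies within the scatter) rests on a limit. Compound 2 stands at a limit: the limit of > 8000 nM in this assay, at which 1 of the 4 values shown sits.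

The compounds shown leave open whether 4-ethoxyphenyl would behave like 2-ethoxyphenyl, which would separate the ethoxy group from its place on the ring. They also leave open how a phenyl bearing an amine or a carboxylic acid would read out on this nitrogen.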